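Phenyl fluorine pattern and larval activity in a small series

The compounds below may be only part of what the source reports. "The series", "measured", "known", "first", "only" and "open" are said of these compounds alone.

Measured so far:
compound 1, `COc1c(F)c(F)cc(-c2nnc(COc3cnn(C(C)(C)C)c(=O)c3Cl)o2)c1F`, gives a limit of the assay only: > 299000 nM
compound 2, `CC(C)(C)n1ncc(OCc2nnc(-c3cc(F)c(F)cc3F)o2)c(Cl)c1=O`, gives 75700 nM

In a functional assay on the whole organism for inhibition, with Mythimna separata as the target, with a stated time of 5 days (a higher number here means that more compound is needed for the effect, a lower number that less compound is needed), compound 2 holds the only number shown; the other value sits at a limit (the limit of > 299000 nM in this assay, at which 1 of the 2 values shown sits). Within the data shown here, the one measured step, an at least 3.9-fold lower number from compound 1 to compound 2 (0.59 log units; beyond the scatter), came from hydrogen in place of methoxy on an aromatic carbon and was at least modest.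

Compound 3, `CC(C)(C)n1ncc(OCc2nnc(-c3ccccc3F)o2)c(Cl)c1=O`, differs from compound 2 by 2-fluorophenyl in place of 2,4,5-trifluorophenyl on an aromatic carbon. Among the measured compounds shown here, no measured step touches the fluorine count of that phenyl, so the single known step does not bear on this change directly; it only shows that substitution on this ring can move this assay by at least a modest amount. For compound 3 a step of a 1.5-fold higher number from compound 2 to compound 3 (0.16 log units; within the scatter) is expected, toward a somewhat higher number but not clearly beyond the scatter. Compound 3 is therefore estimated at 110000 nM, within a range of 30000 nM to 299000 nM.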

Compound 3, half-maximal effective concentration: 16800 nM
Compound 3: the middle estimate sits 6.5-fold (0.82 log units) above what was measured, and the stated range ends above it.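

In this assay, the change to 2-fluorophenyl gives a 4.5-fold lower number from compound 2 to compound 3 (0.65 log units; beyond the scatter), so the fluorine pattern on the phenyl at this carbon of the five-membered ring does matter, and the simpler pattern gives the lower number. Together with an at least 3.9-fold lower number from compound 1 to compound 2 (0.59 log units; beyond the scatter), this makes two steps in which substituents leave the phenyl and the number falls, and neither of the three compounds goes against that trend. Compound 1 remains a limit of the assay, not a number: the limit of > 299000 nM in this assay, at which 1 of the 3 values shown sits.

On these data alone, the two fluorines that leave from compound 2 to compound 3 do so together, so their separate contributions remain open. Also open, as far as these compounds go, is how an unsubstituted phenyl, or a phenyl bearing chlorine, a methyl group or an amine, would read in this assay.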